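The compounds below may be only part of what the source reports. "The series", "measured", "known", "first", "only" and "open" are said of these compounds alone.

In a functional assay on CEM-DNR-bulk cells (Homo sapiens), read by MTT assay, with a stated time of 72 h (on this read-out higher numbers stand for weaker inhibition and lower numbers for stronger inhibition), compound 1 `Nc1nc(N)c2c(-c3ccsc3)cn([C@@H]3O[C@H](CO)[C@@H](O)[C@H]3O)c2n1`, which carries thiophen-3-yl, reads > 20000 nM, a limit of the assay and not a number. Compound 2 `Cc1nc(N)c2c(-c3cccs3)cn([C@@H]3O[C@H](CO)[C@@H](O)[C@H]3O)c2n1` reads > 20000 nM, also only a limit. That places compound 2 at the limit of > 20000 nM in this assay, at which 2 of the 2 values shown sit. Compound 3 `Cc1nc(N)c2c(-c3ccsc3)cn([C@@H]3O[C@H](CO)[C@@H](O)[C@H]3O)c2n1` differs from compound 2 in one place: thiophen-3-yl in place of thiophen-2-yl on an aromatic carbon. With no number yet available on either side of this change, the expected step is a number no higher from compound 2 to compound 3 (the limit leaves the size open), with no clear direction and nothing beyond the scatter anticipated. For compound 3 the estimated value in this assay is 20000 nM, within an expected range of 6000 nM to 40000 nM.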

Compound 3, half-maximal inhibitory concentration: > 20000 nM
Compound 3 was reported as a limit; the forecaster's own chance of this, stated with the estimate: 75%; the middle value sits exactly at the limit.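

Compound 3, like compound 1 and compound 2, gives only a limit of the assay and not a number, so neither step to compound 3 can be read: the limit of > 20000 nM in this assay, at which 3 of the 3 values shown sit.

The compounds shown leave open how thiophen-3-yl compares with thiophen-2-yl, and methyl with amino, in this assay.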